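Two Matched Furofuran Bis-Ketones and an Unmeasured Demethylated Analogue

A few compounds are considered here, and "the series" means these few. Any claim that something is new, unique, unknown or untested is made for them only; others in the source may bear on it.

compound 1 `O=C(CCc1ccc(O)cc1)C[C@@H]1O[C@@H](c2ccc(O)cc2)[C@H]2[C@@H]1[C@H](c1ccc(O)cc1)O[C@H]2CC(=O)CCc1ccc(O)cc1`: 101%
compound 2 `COc1cc([C@@H]2O[C@@H](CC(=O)CCc3ccc(O)cc3)[C@@H]3[C@H]2[C@H](CC(=O)CCc2ccc(O)cc2)O[C@H]3c2ccc(O)c(OC)c2)ccc1O`: 101%

In a functional assay on BV-2 cells (Mus musculus), with stated times of 2 h and 24 h, tested at 1 uM (a higher number here means a weaker effect of the compound at the concentration tested, a lower number a stronger effect), compound 1 gives 101%, and in the same assay compound 2 gives 101%, level with compound 1 within the scatter. Compound 3 `COc1cc([C@@H]2O[C@@H](CC(=O)CCc3ccc(O)cc3)[C@@H]3[C@H]2[C@H](CC(=O)CCc2ccc(O)cc2)O[C@H]3c2ccc(O)cc2)ccc1O` has not yet been measured. The change from compound 2 to compound 3 is hydrogen in place of methoxy on an aromatic carbon, that is, 4-hydroxy-3-methoxyphenyl becomes 4-hydroxyphenyl on one ring. Compounds 1 and 2 both sit at full activity, so no step beyond the scatter is expected in this assay. Compound 3 is estimated at 100%, between 88% and 112%, the expected step being a number 1 percentage points lower from compound 2 to compound 3 (within the scatter).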

Compound 3, a percentage reported as activity, at one concentration (the size of the read-out at that concentration, not a potency): 99.6%
Compound 3: middle estimate off by 0.4 percentage points, on the high side, within the range that was stated.
By their numbers in this assay, from the lowest: compounds 3, 1 and 2 (each within the scatter of the next).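

In this assay the aromatic carbon ortho to a hydroxy group can now be read through single changes: hydrogen in place of methoxy gives a number 1.4 percentage points lower from compound 2 to compound 3 (within the scatter) and methoxy in place of hydrogen gives a number 1.4 percentage points lower from compound 1 to compound 3 (within the scatter) at this kind of position. So the exchange leaves the read-out unchanged within the scatter in both directions, which the earlier compounds could not show, since they differ in more than one place. No available evidence accounts for this result.

From the compounds shown here alone, whether an amine or a carboxylic acid at this carbon would shift the read-out remains open. So does whether any change to the ketone chains would.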